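An acetyl-to-sulfinyl swap on the shared core

This account rests on a few compounds, and the source may have more. Where it says the series, first, only, none or still open, it means among the compounds named here.

Measured in an assay on blood for inhibition of Polyunsaturated fatty acid 5-lipoxygenase (Homo sapiens) (a lower number here means a stronger inhibitor, a higher number a weaker inhibitor), so far:
compound 1 `CC(=O)C1(c2cc(F)cc(OCc3ccc(-n4ccnc4C)cc3)c2)CCOCC1` gives 130 nM
compound 2 `CNC(=O)C1(c2cc(F)cc(OCc3ccc(-n4ccnc4C)cc3)c2)CCOCC1` gives 280 nM

Compound 1 holds the lowest of the two numbers; its nearest neighbour is compound 2, with a 2.2-fold higher number from compound 1 to compound 2 (0.33 log units; beyond the scatter). Compound 3 `Cc1nccn1-c1ccc(COc2cc(F)cc(C3([S+](C)[O-])CCOCC3)c2)cc1` differs from compound 1 in one way: a group of 3 heavy atoms (1 carbon, 1 oxygen, 1 sulfur; no ring) in place of a group of 3 heavy atoms (2 carbon, 1 oxygen; no ring), on a saturated ring carbon. Going by the values given here, the single measured step, a 2.2-fold higher number from compound 1 to compound 2 (0.33 log units; beyond the scatter), also alters the group on that saturated ring carbon but keeps a carbonyl, so it bears only loosely on this swap. A modest upward step is therefore expected, a 1.9-fold higher number from compound 1 to compound 3 (0.28 log units; within the scatter). Compound 3 is estimated at 250 nM, with a range from 80 nM to 800 nM.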

Compound 3, half-maximal inhibitory concentration: > 1000 nM
Compound 3: only a limit was reported; the forecaster's own chance of this, stated with the estimate: 5%; middle value at least 4.0-fold (0.60 log units) away from the limit.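

Compound 3 is recorded only as a limit of the assay: the limit of > 1000 nM in this assay, at which 1 of the 3 values shown sits. On the saturated ring carbon, the sulfur-bearing group in place of acetyl gives an at least 7.6-fold higher number from compound 1 to compound 3 (0.88 log units; beyond the scatter), and in place of the amide group of compound 2 it gives an at least 3.5-fold higher number from compound 2 to compound 3 (0.55 log units; beyond the scatter). Both carbonyl-bearing groups therefore give lower numbers than the sulfur-bearing group, a gap at this position much wider than the earlier pair suggested.

Going by these compounds, how far compound 3 lies past its limit stays unknown. On these data alone, whether a sulfone, a nitrile or a hydroxyl on that carbon would bring the number back towards that of compound 1 also stays open.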